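Capping the Free Amine of Compound 3 with an Acyl Group

The source may report more compounds than this note shows. Statements on the series, on what has been measured and on what is new or still open speak of the compounds shown alone.

Of the compounds shown here, three that share one core have been tested in an assay (strain Wistar) for displacement of a labelled ligand from adenosine receptor A1 (Rattus norvegicus), read by scintillation counting; on this read-out higher numbers stand for weaker inhibition and lower numbers for stronger inhibition. Compound 3 `Nc1nc(-c2ccccc2)nc2c1nnn2Cc1ccccc1`, which carries a free amino group on the core, gives 5.6 nM, the lowest number of the three. Compound 1 `O=C(Nc1nc(-c2ccccc2)nc2c1nnn2Cc1ccccc1)c1cccc([N+](=O)[O-])c1`, in which that nitrogen carries a (3-nitrophenyl)carbonyl group, gives 77 nM, and compound 2 `COc1ccccc1C(=O)Nc1nc(-c2ccccc2)nc2c1nnn2Cc1ccccc1`, with a (2-methoxyphenyl)carbonyl group on the same nitrogen, gives 1520 nM. Removing the acyl group was a large gain in both cases: a 14-fold lower number from compound 1 to compound 3 (1.14 log units; beyond the scatter) and a 270-fold lower number from compound 2 to compound 3 (2.43 log units; beyond the scatter). Between the two acylated compounds, a 20-fold higher number from compound 1 to compound 2 (1.30 log units; beyond the scatter).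

Compound 4 `O=C(Nc1nc(-c2ccccc2)nc2c1nnn2Cc1ccccc1)c1cccc(F)c1` makes the reverse move from compound 3: (3-fluorophenyl)carbonyl in place of hydrogen on a nitrogen on an aromatic ring. Since both acyl groups seen so far raised the number, a rise in this assay is expected here as well, in a size closer to the step seen with compound 1, whose value was 77 nM, than with compound 2. The expected step is a 21-fold higher number from compound 3 to compound 4 (1.33 log units; beyond the scatter). Compound 4 is therefore estimated at 120 nM, with a range from 30 nM to 500 nM.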

Compound 4, inhibition constant: 22 nM
Compound 4: the middle estimate sits 5.5-fold (0.74 log units) above what was measured; measured number below the stated range.
By their numbers in this assay, from the lowest: compound 3; then compound 4; then compound 1; then compound 2.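

In this assay, going by these compounds alone, an acyl group on this nitrogen proves far less costly than the earlier compounds suggested: the (3-fluorophenyl)carbonyl group gives a 3.9-fold higher number from compound 3 to compound 4 (0.59 log units; beyond the scatter), a modest rise that is still beyond the scatter. The group on the carbonyl carbon largely sets the size of that cost, as fluoro in place of nitro on an aromatic carbon gives a 3.5-fold lower number from compound 1 to compound 4 (0.54 log units; beyond the scatter) and 3-fluorophenyl in place of 2-methoxyphenyl on a carbonyl carbon gives a 69-fold lower number from compound 2 to compound 4 (1.84 log units; beyond the scatter). Nothing measured here explains why these steps differ so much in size.

As far as these compounds go, it remains open how a 3-chlorophenyl or 3-methylphenyl group on the carbonyl carbon would compare with 3-fluorophenyl. From the compounds shown here alone, it is also open whether a small acyl group without a ring, such as acetyl, would bring the number closer to that of compound 3.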